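Chain lengthening on the hydrazone of compound 2

The compounds below may be only part of what the source reports. "The series", "measured", "known", "first", "only" and "open" are said of these compounds alone.

Compound 2 `CCCC/C(C)=N\Nc1nc(-c2cccc([N+](=O)[O-])c2)cs1` gives 520000 nM in a functional assay, with a stated time of 30 min (a lower number here means that less compound is needed, a higher number that more compound is needed for the effect), the highest of the two numbers seen, with compound 1 `C=CCC/C(C)=N\Nc1nc(-c2cccc([N+](=O)[O-])c2)cs1` at 460000 nM close by. Among the measured compounds shown here, the one measured step bears on chain size: a 1.1-fold higher number from compound 1 to compound 2 (0.05 log units; within the scatter). Compound 3 `CCCCCC/C(C)=N\Nc1nc(-c2cccc([N+](=O)[O-])c2)cs1` differs from compound 2 by ethyl in place of hydrogen on a saturated chain carbon, four bonds along the chain from a carbon with a double bond to nitrogen. Since the earlier chain change left the number within the scatter, compound 3 is expected to show no step beyond the scatter, a 1.0-fold lower number from compound 2 to compound 3 (0.02 log units; within the scatter). Compound 3 is therefore estimated at 500000 nM, within 200000 nM to 1300000 nM.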

Compound 3, half-maximal effective concentration: 530000 nM
The estimate for compound 3 lay 1.1-fold (0.03 log units) below the measured number; the measured number falls inside the stated range.
By their numbers in this assay, from the lowest: compounds 1, 2 and 3 (each within the scatter of the next).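

In this assay, ethyl in place of hydrogen, four bonds along the chain from a carbon with a double bond to nitrogen, stays within the scatter: a 1.0-fold higher number from compound 2 to compound 3 (0.01 log units; within the scatter). Butyl in place of vinyl reads the same way, a 1.2-fold higher number from compound 1 to compound 3 (0.06 log units; within the scatter), so the three chains shown cannot be told apart in this assay, whether longer or carrying a double bond. Nothing available here explains these numbers.

The compounds shown leave open whether an amine or a carboxylic acid on this chain would give a step beyond the scatter.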